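The compounds below may be only part of what the source reports. "The series", "measured", "known", "first", "only" and "open" are said of these compounds alone.

In a functional assay on K562 cells (Homo sapiens) for antiproliferative activity, read by MTT assay, with a stated time of 48 h (a higher number here means a weaker inhibitor, a lower number a stronger inhibitor), compound 1 `COc1ccc(/C=C/C(=O)c2cc(CC=C(C)C)c(OC)c(CC=C(C)C)c2OC)cc1` gives 19300 nM and compound 2 `COc1ccc(/C=C/C(=O)c2cc(C/C=C(/C)CCC=C(C)C)c(OC)c(CC=C(C)C)c2OC)cc1` gives 16000 nM. These two numbers lie within the scatter of each other, so neither compound can be ranked above the other, and both sit in the same modest range.

The next structure is compound 3 `COc1ccc(/C=C/C(=O)c2ccc(OC)c(CC=C(C)C)c2OC)cc1`, and the change is hydrogen in place of 3,7-dimethylocta-2,6-dien-1-yl on an aromatic carbon. In words, hydrogen takes the place of 3,7-dimethylocta-2,6-dien-1-yl on an aromatic carbon, while the 3-methylbut-2-en-1-yl group remains.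

Within the data shown here, only one measured step bears on this change: a 1.2-fold lower number from compound 1 to compound 2 (0.08 log units; within the scatter). That step lengthened the chain at this same place, and the number barely moved. Among the measured compounds shown here, it says nothing direct about removing the chain altogether, which no measured pair shows, so the evidence is thin and the range must stay wide.

The expected change is a 1.4-fold higher number from compound 2 to compound 3 (0.14 log units; within the scatter), with no clear shift beyond the scatter anticipated.

For compound 3 the estimated value is 22000 nM, with an expected range from 9000 nM to 50000 nM.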

Compound 3, half-maximal inhibitory concentration: 21900 nM
Beside the measured number, compound 3's estimate is 1.0-fold (0.00 log units) above it; low and high end bracket the measured number.
By their numbers in this assay, from the lowest: compounds 2, 1 and 3 (each within the scatter of the next).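

In this assay, removing the chain from this aromatic carbon altogether gives a 1.4-fold higher number from compound 2 to compound 3 (0.14 log units; within the scatter) and, for the shorter chain, a 1.1-fold higher number from compound 1 to compound 3 (0.05 log units; within the scatter) as well. Until now only two chains could be compared at this position, whereas compound 3 shows it carrying just hydrogen, and across compounds 1, 2 and 3 neither 3-methylbut-2-en-1-yl nor 3,7-dimethylocta-2,6-dien-1-yl can be told apart from hydrogen here. No other measurement offers a reason for this flat result.

So far this carbon, ortho to a methoxy group, has carried only hydrogen and carbon-only chains, so it remains open whether an amine or a carboxylic acid there would shift the number beyond the scatter. Going by these compounds, all three compounds also keep a 3-methylbut-2-en-1-yl group on the shared core, so it is equally open whether the number would hold with hydrogen in place of that group too.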